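This account rests on a few compounds, and the source may have more. Where it says the series, first, only, none or still open, it means among the compounds named here.

Working notes on the series:

- compound 1 `O=C(/C(=C\c1ccc(Cl)cc1)SCc1ccccc1Cl)c1ccc(Cl)cc1`: 12000 nM
- compound 2 `COc1ccc(/C=C(/Sc2ccc(C)cc2)C(=O)c2ccc(Cl)cc2)cc1`: 1000 nM

In a functional assay on DU-145 cells (Homo sapiens) for inhibition, read by trypan blue exclusion, with a stated time of 96 h (a lower number here means a stronger inhibitor of growth, a higher number a weaker inhibitor of growth), compound 2 gives 1000 nM, the lowest of the two numbers. Its nearest neighbour, compound 1, gives 12000 nM, a higher number by a gap beyond the scatter. Within the data shown here, the two measured compounds do not differ in one place only, so no measured step bears directly on the next change.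

The next compound is compound 3 `Cc1ccc(S/C(=C/c2ccc(Cl)cc2)C(=O)c2ccc(Cl)cc2)cc1`. Relative to compound 2, it carries chloro in place of methoxy on an aromatic carbon, para to a large group, so that 4-methoxyphenyl becomes 4-chlorophenyl.

Among the measured compounds shown here, with no matched pair to draw on, the expectation rests on compound 2 at 1000 nM as the anchor. A moderate move toward a higher number in this assay is expected, and a result within the scatter would not be surprising. The expected size is a 2.5-fold higher number from compound 2 to compound 3 (0.40 log units; beyond the scatter). For compound 3 the estimated value is 2500 nM, with an expected range of 700 nM to 9000 nM.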

Compound 3, concentration for 50% growth inhibition: 10000 nM
The estimate for compound 3 lay 4.0-fold (0.60 log units) below the measured number; measured number outside the range, above it.
By their numbers in this assay, from the lowest: compound 2; then compounds 3 and 1 (each within the scatter of the next).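

In this assay, among these compounds, the change from 4-methoxyphenyl to 4-chlorophenyl, on an aromatic carbon para to a large group, gives a 10-fold higher number from compound 2 to compound 3 (1.00 log units; beyond the scatter), the first direct reading at this position, and it shows that the lower number of compound 2 goes with methoxy at this place in this pair. The second step, 4-methylphenyl in place of 2-chlorobenzyl on a sulfur, reads a 1.2-fold lower number from compound 1 to compound 3 (0.08 log units; within the scatter), so with 4-chlorophenyl held constant, these two sulfur groups are not separated in this read-out, a comparison the first two compounds alone could not offer. Nothing at hand accounts for the size of the methoxy step.

Within the compounds shown, methoxy occurs only with 4-methylphenyl on the sulfur, so whether its step would carry over to 2-chlorobenzyl on the sulfur remains open. Also open, as far as these compounds go, is whether the step is particular to methoxy or would extend to an ethoxy, a hydroxy or a dimethylamino group at the same place.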